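A few compounds are considered here, and "the series" means these few. Any claim that something is new, unique, unknown or untested is made for them only; others in the source may bear on it.

Measured so far in a functional assay on A549 cells (Homo sapiens), read by MTT assay, with a stated time of 3 days; on this read-out higher numbers stand for weaker inhibition and lower numbers for stronger inhibition:
Compound 1 `CNc1ncnc2[nH]cc(Sc3cccs3)c12`: 28600 nM
Compound 2 `c1csc(Sc2c[nH]c3ncnc(-c4cccs4)c23)c1`: 16200 nM

Only these two compounds have values, and they lie within the scatter of each other, so compound 2 stands level with compound 1 and the two cannot be ranked. Compound 3 `c1coc(-c2ncnc3[nH]cc(Sc4cccs4)c23)c1` departs from compound 2 in one place, with furan-2-yl in place of thiophen-2-yl on an aromatic carbon.

Within the data shown here, one measured step bears on this change, and it concerns the same aromatic carbon. Thiophen-2-yl in place of methylamino gave a 1.8-fold lower number from compound 1 to compound 2 (0.25 log units; within the scatter). The present swap exchanges one five-membered aromatic ring with 1 hetero atom for another, with the same counts of heavy atoms and hydrogen-bond acceptors. Among the measured compounds shown here, no compound with furan-2-yl has been measured yet, so the direction stays open and no shift beyond the scatter is expected in this assay.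

The estimated change is a 1.1-fold higher number from compound 2 to compound 3 (0.05 log units; within the scatter), which is expected to stay within the scatter. For compound 3 the expected value is 18000 nM, with an estimated range of 8000 nM to 40000 nM.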

Compound 3, half-maximal inhibitory concentration: 11400 nM
Beside the measured number, compound 3's estimate is 1.6-fold (0.20 log units) above it; measured number inside the range.
By their numbers in this assay, from the lowest: compounds 3, 2 and 1 (each within the scatter of the next, the first and the last beyond it).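

In this assay, furan-2-yl in place of thiophen-2-yl on this aromatic carbon gives a 1.4-fold lower number from compound 2 to compound 3 (0.15 log units; within the scatter), so exchanging the sulfur of one five-membered aromatic ring with 1 hetero atom for the oxygen of the other does not separate the two compounds. Furan-2-yl in place of methylamino gives a 2.5-fold lower number from compound 1 to compound 3 (0.40 log units; beyond the scatter), a modest step but the first at this position that lies beyond the scatter, whereas thiophen-2-yl in place of methylamino stayed within it at a 1.8-fold lower number from compound 1 to compound 2 (0.25 log units; within the scatter); the position can therefore register a change in this assay, although compound 2 and compound 3 cannot be ranked. No available evidence accounts for the size of either step.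

The compounds shown leave open whether a phenyl ring, a morpholine or a longer amine chain on this aromatic carbon would move the number further than furan-2-yl does. They also leave open whether the same steps would hold if the thiophene held through sulfur on the shared core gave way to another group, since all three compounds carry it unchanged.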